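Adenosine-like compounds: swapping a bromophenyl for a trifluorophenyl

The compounds below may be only part of what the source reports. "The series", "measured", "known", "first", "only" and "open" are said of these compounds alone.

Measured compounds:
- compound 1 `OC[C@H]1O[C@@H](n2cnc3c(NCc4cccc(F)c4)ncnc32)[C@H](O)[C@@H]1O`: "not determined" (no result reported)
- compound 2 `OC[C@H]1O[C@@H](n2cnc3c(NCc4ccc(Br)cc4)ncnc32)[C@H](O)[C@@H]1O`: > 166000 nM

Two compounds share a sugar-bearing core that carries a benzyl-type group on a nitrogen, and they differ only in what sits on that phenyl ring. In a functional assay on B16 cells (Mus musculus) for antiproliferative activity, with a stated time of 72 h (on this read-out lower numbers stand for stronger inhibition and higher numbers for weaker inhibition), compound 1 gives "not determined" (no result reported), so no number exists for it. In this assay compound 2 gives > 166000 nM, which is a limit of the assay rather than a number. Compound 2 therefore stands at the limit of > 166000 nM in this assay, at which 1 of the 2 values shown sits, the weakest end of what can be reported, with no further number beside it.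

Compound 3 `OC[C@H]1O[C@@H](n2cnc3c(NCc4ccc(F)c(F)c4F)ncnc32)[C@H](O)[C@@H]1O` is the next compound. It differs from compound 2 by 2,3,4-trifluorophenyl in place of 4-bromophenyl on a saturated chain carbon bound to a nitrogen on an aromatic ring. Among the compounds with values here, no measured pair in this set shows what such a change does, so the expectation rests only on where compound 2 stands. The step from compound 2 to compound 3 is expected to be a step that the limit leaves unreadable from compound 2 to compound 3, most likely none beyond the scatter. For compound 3 the expected result in this assay is 200000 nM, with a range from 50000 nM to 800000 nM, and it is likely that again only a limit is reported.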

Compound 3, half-maximal inhibitory concentration: > 166000 nM
Compound 3: a limit, no number; the forecaster's own chance of this, stated with the estimate: 70%; the middle value lies beyond the limit too.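

No step from compound 2 to compound 3 can be read, because each is reported only as a limit and not as a number: the limit of > 166000 nM in this assay, at which 2 of the 3 values shown sit.

The compounds shown leave open whether any group on the phenyl ring gives a measurable number in this assay, and how 4-bromophenyl and 2,3,4-trifluorophenyl truly compare.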